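The compounds below may be only part of what the source reports. "The series", "measured", "known", "first", "only" and "open" are said of these compounds alone.

Compound 1 `COc1cc(OC)c(OC)cc1/C=C/COC(=O)/C=C/c1ccccc1C(F)(F)F`: > 200 mg/kg (a limit, not a number)
Compound 2 `COc1cc(OC)c(OC)cc1/C=C/COC(=O)/C=C/c1ccc(F)cc1`: 167 mg/kg
Compound 3 `COc1cccc(/C=C/C(=O)OC/C=C/c2cc(OC)c(OC)cc2OC)c1`: 247 mg/kg

These doses come from a functional assay on the whole organism (strain Kunming) with Mus musculus as the target, with a stated time of 0.5 h; a higher number here means that more compound is needed for the effect, a lower number that less compound is needed. Only compound 2 and compound 3 have actual numbers, and they lie within the scatter of each other: a 1.5-fold higher number from compound 2 to compound 3 (0.17 log units; within the scatter). Compound 4 `COc1cc(OC)c(OC)cc1/C=C/COC(=O)/C=C/c1ccc(Cl)cc1` has 4-chlorophenyl in place of 3-methoxyphenyl on a double-bonded chain carbon bound to a double-bonded chain carbon.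

Three measured steps change the group at this place. The step of an at least 1.1-fold lower number from compound 1 to compound 2 (0.07 log units; that floor lies within the scatter) gives only a floor. The step that the limit leaves unreadable from compound 1 to compound 3 cannot be sized. Going by the values given here, that leaves a 1.5-fold higher number from compound 2 to compound 3 (0.17 log units; within the scatter) as the only readable guide, and it stays within the scatter. Compound 2 also carries a 4-substituted phenyl, 4-fluorophenyl, and gives 167 mg/kg. No step beyond the scatter is therefore expected, and the expected step is a 1.3-fold lower number from compound 3 to compound 4 (0.11 log units; within the scatter). For compound 4 the estimate in this assay is 190 mg/kg, with an expected range from 100 mg/kg to 350 mg/kg.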

Compound 4, dose for half-maximal effect: 142 mg/kg
The estimate for compound 4 lay 1.3-fold (0.13 log units) above the measured number; the range from low to high includes it.
By their numbers in this assay, from the lowest: compounds 4, 2 and 3 (each within the scatter of the next).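

Going by these compounds alone, with the chloro in place of the fluoro on the same 4-substituted phenyl, this assay gives the first look at one halogen exchanged for another at an aromatic carbon, and the result is a 1.2-fold lower number from compound 2 to compound 4 (0.07 log units; within the scatter). Replacing 3-methoxyphenyl with 4-chlorophenyl on a double-bonded chain carbon gives a 1.7-fold lower number from compound 3 to compound 4 (0.24 log units; within the scatter), so this change of both group and substitution also fails to separate the compounds. The comparison with 2-(trifluoromethyl)phenyl yields only a floor, an at least 1.4-fold lower number from compound 1 to compound 4 (0.14 log units; that floor lies within the scatter), and it rests on a limit rather than a number: the limit of > 200 mg/kg in this assay, at which 1 of the 4 values shown sits.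

Every readable step stays within the scatter, so the numbers do not separate these substituted phenyls. From the compounds shown here alone, whether an amine or a carboxylic acid on the phenyl ring would shift the dose beyond the scatter remains open.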